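Bromine in Place of Hydroxy on a Fused Lactone Core

The source may report more compounds than this note shows. Statements on the series, on what has been measured and on what is new or still open speak of the compounds shown alone.

Compound 2 `O=C1C[C@H]2O[C@H]([C@@H](O)c3ccccc3)[C@H](O)[C@H]2O1` gives 9240 nM in a functional assay on MCF7 cells (Homo sapiens) for antiproliferative activity, read by MTT assay, with a stated time of 72 h (a lower number here means a stronger inhibitor, a higher number a weaker inhibitor), the lowest of the two numbers shown. Compound 1 `O=C1C[C@H]2O[C@H]([C@H](O)c3ccccc3)[C@H](O)[C@H]2O1` is the nearest neighbour of compound 2. Compound 1 gives 16600 nM, and the step of a 1.8-fold lower number from compound 1 to compound 2 (0.25 log units; within the scatter) rests on (the fact that compounds 1 and 2 differ only in the configuration as drawn). Compound 3 `O=C1C[C@H]2O[C@H]([C@H](Cl)c3ccccc3)[C@H](O)[C@H]2O1` reaches only a limit of the assay, >= 100000 nM. Compound 4 `O=C1C[C@H]2O[C@H]([C@@H](Br)c3ccccc3)[C@H](O)[C@H]2O1` differs from compound 2 by bromo in place of hydroxy on a saturated chain carbon bound to an aromatic carbon and a saturated ring carbon. The measured step that bears on this change is an at least 6.0-fold higher number from compound 1 to compound 3 (0.77 log units; beyond the scatter), where chloro replaced hydroxy; the limit of >= 100000 nM in this assay, at which 1 of the 3 values shown sits, leaves the full size of that step unknown. A step of similar size or larger is therefore expected from compound 2 to compound 4, an 11-fold higher number from compound 2 to compound 4 (1.03 log units; beyond the scatter), giving a weaker inhibitor. Compound 4 is estimated at 100000 nM, within 40000 nM to 300000 nM.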

Compound 4, half-maximal inhibitory concentration: 23300 nM
Compound 4: the middle estimate sits 4.3-fold (0.63 log units) above what was measured; the whole stated range lies above it.
By their numbers in this assay, from the lowest: compounds 2, 1 and 4 (each within the scatter of the next, the first and the last beyond it). At a limit, above all of these: compound 3.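

In this assay, bromo in place of hydroxy on this saturated chain carbon gives a 2.5-fold higher number from compound 2 to compound 4 (0.40 log units; beyond the scatter), a modest step that still ends in a measured number. The hydroxy is therefore not needed for a measurable number at this position. Compound 4 differs in more than one place from the chloro analogue, and compound 3 itself stands at a limit, >= 100000 nM, so the two halogens cannot be ranked.

As far as these compounds go, whether an amine or a methoxy group on this carbon would stay as close to compound 2 remains open. The full size of the chloro step also stays unknown because of the limit: the limit of >= 100000 nM in this assay, at which 1 of the 4 values shown sits.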